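Swapping an Open Diamine for a Methylpiperazine Ring

This account rests on a few compounds, and the source may have more. Where it says the series, first, only, none or still open, it means among the compounds named here.

Compound 1 `CC(O)(C#Cc1ccc2nc(O)cc(-c3cn[nH]c3)c2c1)c1nccs1`: 38.6 nM
Compound 2 `CN(C)CCN(C)c1cc(-c2cn[nH]c2)c2cc(C#CC(C)(O)c3nccs3)ccc2n1`: 160 nM

In an assay for inhibition of mitogen-activated protein kinase kinase kinase 14 (Homo sapiens), read by luminescence and ADP-Glo, with a stated time of 120 min, in the presence of a further agent that is not named here (a lower number here means a stronger inhibitor, a higher number a weaker inhibitor), compound 1 gives 38.6 nM, whereas compound 2 gives 160 nM, the higher of the two numbers and therefore the weaker inhibitor of the pair. Among the measured compounds shown here, the only measured step, a 4.1-fold higher number from compound 1 to compound 2 (0.62 log units; beyond the scatter), shows that putting a larger amine group where a hydroxy stood costs some potency, though not a great deal.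

Compound 3 `CN1CCN(c2cc(-c3cn[nH]c3)c3cc(C#CC(C)(O)c4nccs4)ccc3n2)CC1` keeps that amine position but closes it into a ring: 4-methylpiperazin-1-yl in place of (2-(dimethylamino)ethyl)(methyl)amino on an aromatic carbon. For the measured compounds named here, no measured step covers a change of this kind, and the group that leaves and the group that enters are of the same size and carry the same count of acceptors, so the shift from compound 2 to compound 3 is expected to stay within the scatter, a 1.1-fold lower number from compound 2 to compound 3 (0.03 log units; within the scatter). Compound 3 is estimated at 150 nM in this assay, with a range from 50 nM to 450 nM.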

Compound 3, half-maximal inhibitory concentration: 175 nM
The estimate for compound 3 lay 1.2-fold (0.07 log units) below the measured number, and the stated range covers the measured number.
By their numbers in this assay, from the lowest: compound 1; then compounds 2 and 3 (each within the scatter of the next).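

Closing the open chain into a 4-methylpiperazin-1-yl ring makes no measurable difference at this position in this assay, with a 1.1-fold higher number from compound 2 to compound 3 (0.04 log units; within the scatter). The cost of replacing the hydroxy therefore does not depend on whether the amine group is an open chain or a ring, as the ring form also gives a weaker inhibitor, with a 4.5-fold higher number from compound 1 to compound 3 (0.66 log units; beyond the scatter). Nothing measured here explains why the hydroxy form gives the lower number.

As far as these compounds go, it remains open whether a smaller group at this position, such as a plain amino group or a methoxy group, would bring the number back towards that of compound 1 at 38.6 nM. It is equally unclear whether a morpholin-4-yl ring, with an oxygen in place of the methyl-bearing nitrogen, would read like the 4-methylpiperazin-1-yl ring.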